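The compounds below may be only part of what the source reports. "The series", "measured", "known", "first", "only" and "open" are said of these compounds alone.

The three measured compounds and their values:

Compound 1, `CC1(C)CC(NC(=S)Nc2ccc(C#N)cc2)c2cc(F)ccc2O1`, gives 19000 nM in a functional assay on T98G cells (Homo sapiens) for inhibition, read by MTT assay, with a stated time of 72 h; on this read-out higher numbers stand for weaker inhibition and lower numbers for stronger inhibition.
Compound 2, `CC1(C)CC(NC(=S)Nc2ccc([N+](=O)[O-])cc2)c2cc(F)ccc2O1`, gives 5000 nM in this assay.
Compound 3, `CC1(C)CC(NC(=S)Nc2cccc([N+](=O)[O-])c2)c2cc(Cl)ccc2O1`, gives 4000 nM in this assay.

Compound 2 and compound 1 share one core and differ in a single place: cyano in place of nitro on an aromatic carbon. That change produced a 3.8-fold higher number from compound 2 to compound 1 (0.58 log units; beyond the scatter). Compound 3 has a different core; how it differs from compound 2 is not broken down here, and their two values lie within the usual scatter of each other. Compound 3 holds the lowest number of the three, though only its gap to compound 1 is beyond the scatter.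

Compound 4, `CC1(C)CC(NC(=S)Nc2cccc(C#N)c2)c2cc(Cl)ccc2O1`, has not yet been measured in this assay. It arises from compound 3 by the same kind of change that turns compound 2 into compound 1: cyano in place of nitro on an aromatic carbon. The change is the same kind rather than the same, since in compound 1 the cyano stands para to a large group, whereas in compound 4 it stands meta to a large group.

Resting on the one measured instance of this change, compound 4 is expected to show a 3.0-fold higher number from compound 3 to compound 4 (0.48 log units; beyond the scatter), in the same direction as the step from compound 2 to compound 1 because that step was a 3.8-fold higher number from compound 2 to compound 1 (0.58 log units; beyond the scatter). The estimate for compound 4 is therefore 12000 nM, with a range from 5000 nM to 35000 nM.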

Compound 4, half-maximal inhibitory concentration: 10000 nM
Beside the measured number, compound 4's estimate is 1.2-fold (0.08 log units) above it; low and high end bracket the measured number.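

In this assay, cyano in place of nitro gave a 2.5-fold higher number from compound 3 to compound 4 (0.40 log units; beyond the scatter), so the change ran the same way on the second core as on the first. In both pairs the cyano compound carries the higher number, which on this read-out means weaker inhibition, and the two steps also agree in size: the same change on two cores in this assay, a 3.8-fold higher number (0.58 log units; beyond the scatter) from compound 2 to compound 1 and a 2.5-fold higher number (0.40 log units; beyond the scatter) from compound 3 to compound 4, 1.5-fold (0.18 log units) apart, within the scatter of two such steps

This agreement shows that, for these two pairs, the step carried over from one core to the other, but two pairs are a narrow base for any rule about the series, and they say nothing about why the number rises. In compound 4 the cyano stands meta to a large group, while in the other pair it stands elsewhere, so the data cannot separate any contribution of the core from one of that place.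

What the compounds shown leave open is whether other replacements for nitro, such as an amine, a carboxylic acid or trifluoromethyl, would move the number in the same way. Also open, going by these compounds, is how the nitro and cyano pair would behave with both placements on a single core, or on a core carrying a methoxy group instead of the halogen.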